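Methoxy for Methyl on the Benzyl Ring

The source may hold more compounds than are shown below. What is called first, only, known or untested is meant among the compounds shown, and "the series" means these compounds.

Three compounds share one core, a hydroxymethyl-bearing indole carrying a benzyl group, and differ only on the far six-membered ring. In a functional assay on NCI-H460 cells (Homo sapiens) for cytotoxicity, read by sulforhodamine B assay, with a stated time of 3 days (a lower number here means a stronger inhibitor, a higher number a weaker inhibitor), compound 1 `OCc1cn(Cc2ccccc2)c2ccccc12` gives 112 nM. Compound 2 `OCc1cn(Cc2ccc(Cl)cc2)c2ccccc12` gives 16 nM in this assay, and compound 3 `Cc1ccc(Cn2cc(CO)c3ccccc32)cc1` gives 31 nM. The two measured changes on that ring both helped: a 7.0-fold lower number from compound 1 to compound 2 (0.85 log units; beyond the scatter), and a 3.6-fold lower number from compound 1 to compound 3 (0.56 log units; beyond the scatter). Between the two substituted compounds, a 1.9-fold higher number from compound 2 to compound 3 (0.29 log units; within the scatter), so compound 3 stands second highest of the three numbers, close to compound 2 and clearly apart from compound 1.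

Compound 4 `COc1ccc(Cn2cc(CO)c3ccccc32)cc1` is not yet measured. Compared with compound 3 it has methoxy in place of methyl on an aromatic carbon. Going by the values given here, no measured step here involves methoxy, so the only guidance is that the two groups already placed at this position gave modest gains over the unsubstituted compound 1, and the step from compound 2 to compound 3 sat within the scatter. Compound 4 is therefore expected to land near compound 3, with a 1.3-fold higher number from compound 3 to compound 4 (0.11 log units; within the scatter) as the likely outcome in this assay. Compound 4 is estimated at 40 nM, expected between 12 nM and 130 nM.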

Compound 4, half-maximal inhibitory concentration: 79 nM
Estimate against measurement, compound 4: 2.0-fold (0.30 log units) below, within the range that was stated.
By their numbers in this assay, from the lowest: compounds 2 and 3 (each within the scatter of the next); then compounds 4 and 1 (each within the scatter of the next).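

Until now, both groups placed at this position had lowered the number in this assay relative to the unsubstituted compound, which could suggest that any group there would help, but methoxy does not fit that reading: with a 1.4-fold lower number from compound 1 to compound 4 (0.15 log units; within the scatter), compound 4 cannot be told apart from compound 1. The exact group therefore matters, as a 2.5-fold higher number from compound 3 to compound 4 (0.41 log units; beyond the scatter) and a 4.9-fold higher number from compound 2 to compound 4 (0.69 log units; beyond the scatter) are both steps beyond the scatter, so methoxy, with its added oxygen and one hydrogen-bond acceptor, does not keep the gain seen with methyl and chloro. Nothing in the available data accounts for this difference between the groups.

The compounds shown leave open how an amine, a nitrile, a trifluoromethyl group or a longer chain such as ethoxy would read at this same position. They also leave open whether methoxy, methyl and chloro would keep this order at other places on the ring, as every change here sits at the one place, para to a large group.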